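Swapping the sulfonamide ring: an estimate for compound 4

The compounds below may be only part of what the source reports. "The series", "measured", "known", "first", "only" and "open" are said of these compounds alone.

Compound 1 `Cc1cc(C)nc(NS(=O)(=O)c2ccc(Nc3nncc4ccccc34)cc2)n1`: 7.8 nM
Compound 2 `O=S(=O)(Nc1ncccn1)c1ccc(Nc2nncc3ccccc23)cc1`: 45 nM
Compound 3 `O=S(=O)(Nc1nccs1)c1ccc(Nc2nncc3ccccc23)cc1`: 24 nM

In a functional assay on DU-145 cells (Homo sapiens) for antiproliferative activity, read by sulforhodamine B assay, with a stated time of 72 h (on this read-out lower numbers stand for stronger inhibition and higher numbers for weaker inhibition), compound 3 stands second highest of the three numbers. There is a 1.9-fold lower number from compound 2 to compound 3 (0.27 log units; within the scatter), and there is a 3.1-fold higher number from compound 1 to compound 3 (0.49 log units; beyond the scatter). Compound 4 `O=S(=O)(Nc1ccccn1)c1ccc(Nc2nncc3ccccc23)cc1` remains unmeasured and differs thus: pyridin-2-yl in place of 1,3-thiazol-2-yl on a sulfonamide nitrogen. In words, pyridin-2-yl stands in place of 1,3-thiazol-2-yl on a sulfonamide nitrogen. Going by the values given here, the closest precedent is the exchange between the two unsubstituted rings, which stayed within the scatter. Among the compounds with values here, the larger steps, a 5.8-fold higher number from compound 1 to compound 2 (0.76 log units; beyond the scatter) and the one to compound 3, both leave 4,6-dimethylpyrimidin-2-yl, which plays no part here. No step beyond the scatter is therefore expected in this assay. The expected change is a 1.3-fold higher number from compound 3 to compound 4 (0.10 log units; within the scatter). Compound 4 is estimated at 30 nM, with an expected range of 11 nM to 80 nM.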

Compound 4, half-maximal inhibitory concentration: 54 nM
The estimate for compound 4 lay 1.8-fold (0.26 log units) below the measured number; low and high end bracket the measured number.
By their numbers in this assay, from the lowest: compound 1; then compounds 3, 2 and 4 (each within the scatter of the next, the first and the last beyond it).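

In this assay, the ring on the sulfonamide nitrogen now shows a step among the unsubstituted rings (a 2.3-fold higher number from compound 3 to compound 4 (0.35 log units; beyond the scatter)), where pyrimidin-2-yl and 1,3-thiazol-2-yl had stayed within the scatter of each other. Pyridin-2-yl and pyrimidin-2-yl cannot be told apart (a 1.2-fold higher number from compound 2 to compound 4 (0.08 log units; within the scatter)), while compound 1 keeps the lowest number of the four (for pyridin-2-yl, a 6.9-fold higher number from compound 1 to compound 4 (0.84 log units; beyond the scatter)). No evidence here explains these differences.

The compounds shown leave open how a pyridin-2-yl ring carrying two methyl groups would read, and how one carrying an amine or a methoxy group would compare.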